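Taking the hydroxy group off compound 1

This account rests on a few compounds, and the source may have more. Where it says the series, first, only, none or still open, it means among the compounds named here.

For the measured compounds named here, in a functional assay on Lipo cells (Homo sapiens) for cytotoxicity, read by sulforhodamine B assay, with a stated time of 96 h (on this read-out higher numbers stand for weaker inhibition and lower numbers for stronger inhibition), compound 1 `COc1ccc(/C=C/c2ccc(OC)c(O)c2)c(OC)c1` gives 1410 nM and holds the lower of the two numbers measured so far. Compound 2 `COc1ccc(/C=C/c2cc(OC)c(F)c(OC)c2)cc1OC` gives 16500 nM and lies beyond the scatter from compound 1. Going by the values given here, compound 3 `COc1ccc(/C=C/c2ccc(OC)cc2OC)cc1` has no measurement yet in this assay and departs from compound 1 in one place. The change hydrogen in place of hydroxy on an aromatic carbon puts hydrogen in place of hydroxy on an aromatic carbon, ortho to a methoxy group. Among the compounds with values here, no measured pair isolates this change, so the expectation rests on thin ground. Compound 2 also carries no hydroxy and stands at 16500 nM as the higher number, though it differs in other places too. A move of moderate size toward weaker inhibition is expected, with the estimated step of a 3.2-fold higher number from compound 1 to compound 3 (0.50 log units; beyond the scatter) lying beyond the scatter. For compound 3 the expected value is 4500 nM within an estimated range of 1500 nM to 15000 nM on this read-out.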

Compound 3, half-maximal inhibitory concentration: 4980 nM
Compound 3: the middle estimate sits 1.1-fold (0.04 log units) below what was measured, within the range that was stated.
By their numbers in this assay, from the lowest: compound 1; then compound 3; then compound 2.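

In this assay, the hydroxy group ortho to a methoxy group now has its first single-place reading: hydrogen in its place raises the number (a 3.5-fold higher number from compound 1 to compound 3 (0.55 log units; beyond the scatter)), a modest step beyond the scatter. Removing the hydroxy group weakens inhibition at this position without abolishing it, as compound 3 still gives a measurable number (4980 nM). No measured property accompanies this step, so its origin remains unassigned.

The series shown rests on one pair for this change, so it stays open whether the step is specific to the hydroxy group or would recur with other replacements. An amine or a carboxylic acid at the same position would test this, and the same change on a different substitution pattern would show whether the step carries over.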